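Lengthening an Amide Chain: Expected Cytotoxicity

The source may hold more compounds than are shown below. What is called first, only, known or untested is meant among the compounds shown, and "the series" means these compounds.

Measured compounds in an ADME assay on L929 cells (Mus musculus, culture collection number NCTC 929) for cytotoxicity, read by MTT assay, with a stated time of 72 h; on this read-out higher numbers stand for weaker inhibition and lower numbers for stronger inhibition:
compound 1 `Cc1cc(O)c(C(=O)NCCCc2ccccc2)c(=O)o1` gives 143000 nM
compound 2 `CCCCCCCCCCCCCC(=O)c1c(O)cc(C)oc1=O` gives a limit of the assay, > 200000 nM
compound 3 `CCCCCCNC(=O)c1c(O)cc(C)oc1=O` gives 196000 nM

Compound 3 holds the highest of the two numbers in this assay; its nearest neighbour is compound 1, with a 1.4-fold higher number from compound 1 to compound 3 (0.14 log units; within the scatter). Compound 4 `CCCCCCCCCCCCCCNC(=O)c1c(O)cc(C)oc1=O` differs from compound 3 in one place: octyl in place of hydrogen on a saturated chain carbon, six bonds along the chain from an amide-type nitrogen. Among the compounds with values here, the only measured step, a 1.4-fold higher number from compound 1 to compound 3 (0.14 log units; within the scatter), alters a different part of the chain and stays within the scatter, so it gives little guidance. Compound 2 sits at a limit, (the limit of > 200000 nM in this assay, at which 1 of the 3 values shown sits). Compound 4 is therefore expected to stay near the top of this range, with a 1.0-fold higher number from compound 3 to compound 4 (0.01 log units; within the scatter). The estimate for compound 4 is 200000 nM, spanning 100000 nM to 400000 nM.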

Compound 4, half-maximal inhibitory concentration: > 200000 nM
Compound 4: no number, only a limit; the forecaster's own chance of this, stated with the estimate: 60%; the middle value lies on the limit itself.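

In this assay compound 4 gives > 200000 nM, which is a limit and not a number. The step, an at least 1.0-fold higher number from compound 3 to compound 4 (0.00 log units; that floor lies within the scatter), therefore sets only a floor: octyl in place of hydrogen at this chain carbon brings no sign of stronger inhibition. With this longer amide chain, the limit is no longer held by compound 2 alone: the limit of > 200000 nM in this assay, at which 2 of the 4 values shown sit.

Going by these compounds, how far compound 4 lies beyond the limit stays unknown. On these data alone, whether an amine or a carboxylic acid on this saturated chain would give a number within the measurable range also remains open.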